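The compounds below may be only part of what the source reports. "The series", "measured", "known", "first", "only" and "open" are said of these compounds alone.

Of the compounds shown here, three have so far been measured in a functional assay on A549 cells (Homo sapiens) for cytotoxicity, read by MTT assay; on this read-out higher numbers stand for weaker inhibition and lower numbers for stronger inhibition. Compound 1 `CC(C)[C@H](NC(=S)Nc1cc(C(F)(F)F)cc(C(F)(F)F)c1)c1nc2ccccc2[nH]1` gives 25100 nM in this assay. Compound 2 `C[C@H](NC(=S)Nc1cc(C(F)(F)F)cc(C(F)(F)F)c1)c1nc2ccccc2[nH]1` differs from compound 1 in a single place:

methyl in place of isopropyl on a saturated chain carbon bound to an amide-type nitrogen and an aromatic carbon

That change produced an 8.8-fold higher number from compound 1 to compound 2 (0.94 log units; beyond the scatter). Compound 2 gives 220000 nM in this assay.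

Compound 3 `CC(C)[C@@H](NC(=S)NCc1ccccc1)c1nc2ccccc2[nH]1` is built on a different core; the difference between the core of compound 1 and the core of compound 3 is not broken down here. In this assay compound 3 gives 11300 nM, the lowest number of the three, with compound 1 next and compound 2 furthest away.

Compound 4 `C[C@@H](NC(=S)NCc1ccccc1)c1nc2ccccc2[nH]1` has not yet been measured. It differs from compound 3 as follows:

methyl in place of isopropyl on a saturated chain carbon bound to an amide-type nitrogen and an aromatic carbon

This is the same change that turns compound 1 into compound 2, and it sits at a place described in exactly the same words, only on the other core. If the change acts alike on both cores, the number for compound 4 should rise above that of compound 3 by a comparable amount. Compound 4 is therefore expected to give about 80000 nM in this assay, most likely between 30000 nM and 250000 nM. Going by the values given here, that expectation amounts to a 7.1-fold higher number from compound 3 to compound 4 (0.85 log units; beyond the scatter), and it rests on the single earlier example, because an 8.8-fold higher number from compound 1 to compound 2 (0.94 log units; beyond the scatter) is the only measured instance of this change, so a wide range is kept.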

Compound 4, half-maximal inhibitory concentration: 18700 nM
Estimate against measurement, compound 4: 4.3-fold (0.63 log units) above; the whole stated range lies above it.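

In this assay, methyl in place of isopropyl gives a 1.7-fold higher number from compound 3 to compound 4 (0.22 log units; within the scatter), so on the core of compound 3 this change has no effect that can be told apart from the ordinary spread of repeated measurements. Set beside the earlier pair, the change clearly does not carry over at the same size from one core to the other: the same change on two cores in this assay, an 8.8-fold higher number (0.94 log units; beyond the scatter) from compound 1 to compound 2 and a 1.7-fold higher number (0.22 log units; within the scatter) from compound 3 to compound 4, 5.3-fold (0.72 log units) apart, beyond the scatter of two such steps. Going by these compounds alone, this shows that a step measured on one core cannot simply be copied onto the other, but with only two pairs it does not show which difference between the cores matters, how the size of the step is set, or whether either pair is typical of the wider series.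

The compounds shown leave open whether an ethyl group or a longer chain, on the same saturated chain carbon bound to an amide-type nitrogen and an aromatic carbon, would behave on each core as methyl and isopropyl do. They also leave open whether an amine or a carboxylic acid at that place would separate the two cores in the same way.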